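Ester chain extension on a stable pyrimidinone core

The source may hold more compounds than are shown below. What is called first, only, known or untested is meant among the compounds shown, and "the series" means these compounds.

The measured compounds and their numbers in an ADME assay on microsomes from liver (Mus musculus) for metabolic stability, with a stated time of 30 min; on this read-out higher numbers stand for a more stable compound and lower numbers for a less stable compound:
Compound 1 `CCCCc1nc(C(C)C)c(CC(=O)OC)c(=O)n1Cc1ccc(-c2ccccc2-c2noc(=O)[nH]2)cc1`: 9.4%
Compound 2 `CCCCc1nc(C(C)C)c(CC(=O)OCC(C)C)c(=O)n1Cc1ccc(-c2ccccc2-c2noc(=O)[nH]2)cc1`: 13.7%
Compound 3 `CCCCc1nc(C)c(CC(=O)OC)c(=O)n1Cc1ccc(-c2ccccc2-c2noc(=O)[nH]2)cc1`: 47.1%

Compound 3 stands highest of the three in this assay, beyond the scatter from both compound 2 and compound 1. The step from compound 1 to compound 3, a number 37.7 percentage points higher from compound 1 to compound 3 (beyond the scatter), is the large one and turns on the aromatic substituent, which compound 4 keeps.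

Compound 4 `CC#CCOC(=O)Cc1c(C)nc(CCCC)n(Cc2ccc(-c3ccccc3-c3noc(=O)[nH]3)cc2)c1=O` differs from compound 3 only at the ester: prop-1-yn-1-yl in place of hydrogen on a saturated chain carbon bound to an oxygen next to a carbonyl group. Going by the values given here, the one measured step that bears on this part of the molecule is the ester change from compound 1 to compound 2, a number 4.3 percentage points higher from compound 1 to compound 2 (within the scatter), which stayed within the scatter. Among the compounds with values here, with that as the sole guide, the step from compound 3 to compound 4 in this assay is expected to be small, a number 2.1 percentage points lower from compound 3 to compound 4 (within the scatter), with no direction claimed beyond the scatter.

Compound 4 is therefore estimated at 45% in this assay, within a range of 25% to 65%.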

Compound 4, percent of the compound remaining: 18.3%
The estimate for compound 4 lay 26.7 percentage points above the measured number, outside the stated range (below it).
By their numbers in this assay, from the lowest: compounds 1, 2 and 4 (each within the scatter of the next); then compound 3.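

In this assay, the ester position turns out not to be silent: with methyl on the aromatic carbon, replacing methoxy with (but-2-yn-1-yl)oxy gives a number 28.8 percentage points lower from compound 3 to compound 4 (beyond the scatter). The only earlier ester change, made with isopropyl on that aromatic carbon, gave a number 4.3 percentage points higher from compound 1 to compound 2 (within the scatter), so a small step at this position does not hold across the two ester changes shown, though these differ in both the ester and the aromatic substituent. No measurement here accounts for the drop.

The compounds shown leave open whether the lower number goes with the triple bond or with the longer chain, which a saturated butyl ester on the same core would separate. As far as these compounds go, it also remains open how the free carboxylic acid would read, and whether the but-2-yn-1-yl ester would give a step of this size with isopropyl on the aromatic carbon.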